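Removing two fluorines from a sulfonyl-linked aryl ring

A few compounds are considered here, and "the series" means these few. Any claim that something is new, unique, unknown or untested is made for them only; others in the source may bear on it.

Of the compounds shown here, three sharing one core have been tested in an assay on isolated protein for displacement of a labelled ligand from metabotropic glutamate receptor 5 (Homo sapiens), with a stated time of 60 min, tested at 1 uM; on this read-out lower numbers stand for less inhibition and higher numbers for more inhibition at the one concentration tested (going by the name of the read-out). Compound 1 `CC1CCN(c2c(S(=O)(=O)c3cc(F)cc(F)c3)cnc3cc(Cl)ccc23)CC1` gives 94%, the highest of the three numbers. Compound 2 `O=S(=O)(c1cccc(F)c1)c1cnc2cc(Cl)ccc2c1N1CCC(CO)CC1` gives 71%, a number beyond the scatter below compound 1, and compound 3 `COc1ccc2ncc(S(=O)(=O)c3ccc(OC)c(Cl)c3)c(N3CCC(C)CC3)c2c1` gives 21%, further below still. Compound 4 `CC1CCN(c2c(S(=O)(=O)c3ccccc3)cnc3cc(Cl)ccc23)CC1` has not yet been measured. It differs from compound 1 in one place: phenyl in place of 3,5-difluorophenyl on a sulfonyl sulfur. Going by the values given here, no measured pair shows this exact change, so its size is not known. Among the compounds with values here, with only three numbers to go on, a modest fall in this assay is expected, a number 14 percentage points lower from compound 1 to compound 4 (beyond the scatter), since compound 1 already gives 94% and leaves little room upward. Compound 4 is therefore estimated at 80%, within a range of 55% to 95%.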

Compound 4, a percentage reported as inhibition, at one concentration (the size of the read-out at that concentration, not a potency): 93%
For compound 4 the middle estimate is 13 percentage points below the measured one; the range from low to high includes it.
By their numbers in this assay, from the lowest: compound 3; then compound 2; then compounds 4 and 1 (each within the scatter of the next).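

In this assay putting phenyl in place of 3,5-difluorophenyl on a sulfonyl sulfur gives a number 1 percentage points lower from compound 1 to compound 4 (within the scatter) and so the two compounds cannot be told apart. Going by these compounds alone, on this core, then, the high reading survives without either fluorine, something the earlier compounds, which differ in several places at once, could not show. Nothing available here explains this result. Still open, from the compounds shown here alone, is how this position responds to larger changes, such as an amine or a carboxylic acid on the phenyl ring. A single concentration also leaves open whether compound 1 and compound 4 would match across a full range of concentrations.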